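Replacing a Sulfamoyl Group with Difluoromethoxy on a Shared Core

The source may hold more compounds than are shown below. What is called first, only, known or untested is meant among the compounds shown, and "the series" means these compounds.

Of the compounds shown here, three on one shared core have been tested in an in vitro assay on Sf21 cells for inhibition of high affinity 3',5'-cyclic-AMP phosphodiesterase 7A (Homo sapiens), read by scintillation proximity assay, with a stated time of 30 min; on this read-out higher numbers stand for weaker inhibition and lower numbers for stronger inhibition. Compound 1 `Nc1ccc(NC(=O)c2cn(Cc3c(F)cccc3F)c3ccc(=O)[nH]c3c2=O)cc1` gives 104 nM. Compound 2 `O=C(NCc1ccncc1)c1ccc(NC(=O)c2cn(Cc3c(F)cccc3F)c3ccc(=O)[nH]c3c2=O)cc1` gives 20 nM, and compound 3 `O=C(Nc1ccc(S(=O)(=O)Nc2nccs2)cc1)c1cn(Cc2c(F)cccc2F)c2ccc(=O)[nH]c2c1=O` gives 25 nM. Compound 3 therefore sits close to compound 2, since a 1.3-fold higher number from compound 2 to compound 3 (0.10 log units; within the scatter), and clearly apart from compound 1, since a 4.2-fold lower number from compound 1 to compound 3 (0.62 log units; beyond the scatter). Compound 4 `O=C(Nc1ccc(OC(F)F)cc1)c1cn(Cc2c(F)cccc2F)c2ccc(=O)[nH]c2c1=O` differs from compound 3 in one place: difluoromethoxy in place of (1,3-thiazol-2-yl)sulfamoyl on an aromatic carbon. Within the data shown here, no measured step swaps one group for another of this sort, so the nearest guides are a 4.2-fold lower number from compound 1 to compound 3 (0.62 log units; beyond the scatter) and a 5.2-fold lower number from compound 1 to compound 2 (0.72 log units; beyond the scatter), where the amino compound showed the higher number. On that basis compound 4 is expected to give a higher number, with a 3.2-fold higher number from compound 3 to compound 4 (0.51 log units; beyond the scatter). The estimate for compound 4 is 80 nM, within a range of 30 nM to 250 nM.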

Compound 4, half-maximal inhibitory concentration: 71 nM
Beside the measured number, compound 4's estimate is 1.1-fold (0.05 log units) above it, and the stated range covers the measured number.
By their numbers in this assay, from the lowest: compounds 2 and 3 (each within the scatter of the next); then compounds 4 and 1 (each within the scatter of the next).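

Putting difluoromethoxy in place of the bigger (1,3-thiazol-2-yl)sulfamoyl gives a 2.8-fold higher number from compound 3 to compound 4 (0.45 log units; beyond the scatter) and in place of ((pyridin-4-yl)methyl)carbamoyl gives a 3.6-fold higher number from compound 2 to compound 4 (0.55 log units; beyond the scatter), while in place of amino it gives a 1.5-fold lower number from compound 1 to compound 4 (0.17 log units; within the scatter). At this position, then, the two ring-free groups stand apart from the two ring-bearing groups, and difluoromethoxy and amino cannot be told apart. Nothing measured here explains this. Still open, from the compounds shown here alone, is whether a plain phenyl ring at this place would match compound 2 and compound 3, or whether they also need their linking amide or sulfonamide atoms. A carboxylic acid or a longer alkyl chain is also untested among these compounds.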